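The compounds below may be only part of what the source reports. "The series", "measured", "known", "first", "only" and "open" are said of these compounds alone.

Compound 1 `CC(C)Nc1cc(Nc2ccc3ncsc3c2)ncc1C(=O)NC[C@@H](C)C(C)(C)O` has no single number in an ADME assay on microsomes from liver (Homo sapiens) for metabolic stability; on this read-out lower numbers stand for a less stable compound and higher numbers for a more stable compound: for compound 1 the result is "not determined" (no result reported). A closely related compound 2 `CCCNC(=O)c1cnc(Nc2ccc3ncsc3c2)cc1NC(C)C` does have one; in this assay compound 2 gives 52%. Compound 3 `CCNC(=O)c1cnc(Nc2ccc3ncsc3c2)cc1NC(C)C` is reached from compound 1 by a single change: methyl in place of 2-hydroxy-1,2-dimethylpropyl on a saturated chain carbon bound to an amide-type nitrogen. Among the compounds with values here, no measured pair shows what this change does in this assay, so the step cannot be sized from data; judged by compound 2 at 52%, a value near that figure is expected, with any difference likely within the scatter. Compound 3 is expected to give 55%, between 35% and 75%.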

Compound 3, percent of the compound remaining: 74%
Compound 3: middle estimate off by 19 percentage points, on the low side; low and high end bracket the measured number.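

In this assay, within the data shown here, hydrogen in place of methyl on a saturated chain carbon, two bonds along the chain from an amide-type nitrogen, gives a number 22 percentage points higher from compound 2 to compound 3 (beyond the scatter) and makes this the first readable step at this position. So even a one-carbon edit to this amide chain can shift the read-out, though only this single pair shows it. No measurement on hand explains the shift.

Steps involving compound 1 cannot be read. Going by these compounds, whether a cyclopropyl group or a plain methyl at this place would raise the number further remains open.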